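The source may report more compounds than this note shows. Statements on the series, on what has been measured and on what is new or still open speak of the compounds shown alone.

Three amides with a shared core have so far been measured in a functional assay on KB cells (Homo sapiens) for cytotoxicity, read by MTT assay (on this read-out lower numbers stand for stronger inhibition and higher numbers for weaker inhibition), as a guide to what comes next. Compound 1 (`CCn1cc(C(=O)Nc2ccc(Cl)cn2)c(=O)c2cc(F)c(N3CCNC(C)C3)c(F)c21`) gives 1600 nM and compound 2 (`CCn1cc(C(=O)Nc2cccc([N+](=O)[O-])c2)c(=O)c2cc(F)c(N3CCNC(C)C3)c(F)c21`) gives 1700 nM as its value, and these two lie within the scatter of each other. Compound 3 (`CCn1cc(C(=O)Nc2ccc(C)c([N+](=O)[O-])c2)c(=O)c2cc(F)c(N3CCNC(C)C3)c(F)c21`) has the highest number of the three at 3900 nM and so is the weakest of them. Compound 4 (`CCn1cc(C(=O)Nc2ccc(OC(F)(F)F)cc2)c(=O)c2cc(F)c(N3CCNC(C)C3)c(F)c21`) has 4-(trifluoromethoxy)phenyl in place of 4-methyl-3-nitrophenyl on an amide-type nitrogen and has not yet been measured.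

Two measured steps exchange the group at that same place, giving a 1.1-fold higher number from compound 1 to compound 2 (0.03 log units; within the scatter) and a 2.4-fold higher number from compound 1 to compound 3 (0.39 log units; beyond the scatter) as their sizes. Placing methyl in place of hydrogen on an aromatic carbon gives a 2.3-fold higher number from compound 2 to compound 3 (0.36 log units; beyond the scatter) as a third, equally small step. Among the measured compounds shown here, no measured compound carries trifluoromethoxy, so these steps guide only by their size. Since compound 3 at 3900 nM already sits at the top of this small set, a slight lean towards a lower number seems reasonable. The estimated change is a 1.6-fold lower number from compound 3 to compound 4 (0.19 log units; within the scatter) and no step beyond the scatter is expected. The value expected for compound 4 is 2500 nM with an estimated range of 1000 nM to 6000 nM.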

Compound 4, half-maximal inhibitory concentration: 1400 nM
Estimate against measurement, compound 4: 1.8-fold (0.25 log units) above; the measured number falls inside the stated range.
By their numbers in this assay, from the lowest: compounds 4, 1 and 2 (each within the scatter of the next); then compound 3.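

In this assay, the step of a 2.8-fold lower number from compound 3 to compound 4 (0.44 log units; beyond the scatter) shows that a ring with no nitro group and no methyl group, carrying trifluoromethoxy instead, can sit on the amide-type nitrogen without any loss compared with the other amides. The new compound also lies level with the two earlier ones, at a 1.2-fold lower number from compound 2 to compound 4 (0.08 log units; within the scatter) and a 1.1-fold lower number from compound 1 to compound 4 (0.06 log units; within the scatter), both within the scatter, so 5-chloropyridin-2-yl, 3-nitrophenyl and 4-(trifluoromethoxy)phenyl cannot be told apart here, and compound 3 alone stands out as the weakest of the four. No measurement on hand explains why 4-methyl-3-nitrophenyl gives the higher number.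

All four groups on this nitrogen are six-membered aromatic rings, so the compounds shown leave open whether a saturated ring such as cyclohexyl, or a plain chain such as butyl, would hold the same level. They also leave open how a ring bearing an amine or a carboxylic acid would behave, and whether the methyl group would raise the number on a ring with trifluoromethoxy as it does on the ring with the nitro group.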